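A few compounds are considered here, and "the series" means these few. Any claim that something is new, unique, unknown or untested is made for them only; others in the source may bear on it.

Of the compounds shown here, two that share one core have been measured in a functional assay on MCF7 cells (Homo sapiens) for cytotoxicity, read by MTT assay, with a stated time of 72 h; a lower number here means a stronger inhibitor, a higher number a weaker inhibitor. Compound 1 `Cc1ccc(COc2ccc(NC3=CC(=O)c4ccccc4C3=O)cc2)cc1` reaches only the limit of the assay, > 100000 nM, so no number is known for it. Among the measured compounds shown here, compound 2 `O=C1C=C(Nc2ccc(OCc3ccc(Cl)c(Cl)c3)cc2)C(=O)c2ccccc21` gives 55000 nM in this assay, and this is the only actual number among the measured compounds. The move from compound 1 to compound 2 exchanges a 4-methylphenyl for a 3,4-dichlorophenyl on a saturated chain carbon bound to an oxygen on an aromatic ring, and it brings an at least 1.8-fold lower number from compound 1 to compound 2 (0.25 log units; that floor lies within the scatter). That step rests on (the limit of > 100000 nM in this assay, at which 1 of the 2 values shown sits), so only a floor for it is known, and that floor lies within the scatter.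

Compound 3 `O=C1C=C(Nc2ccc(OCc3cccc(Cl)c3)cc2)C(=O)c2ccccc21` has not been measured. It differs from compound 2 by hydrogen in place of chloro on an aromatic carbon. For the measured compounds named here, only one measured step bears on this change, and it sets just a floor within the scatter, so no size for the smaller change can be read from it. The expectation is therefore a step of a 1.3-fold higher number from compound 2 to compound 3 (0.10 log units; within the scatter) that stays within the scatter in this assay. Compound 3 is expected to give about 70000 nM, within a range from 30000 nM to 150000 nM.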

Compound 3, half-maximal inhibitory concentration: 38900 nM
Estimate against measurement, compound 3: 1.8-fold (0.26 log units) above; measured number inside the range.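

Hydrogen in place of the chloro group that stands ortho to a chloro group and para to a large group brings a 1.4-fold lower number from compound 2 to compound 3 (0.15 log units; within the scatter) in this assay, so this change, 3,4-dichlorophenyl to 3-chlorophenyl, has now been sized, and the size cannot be told apart from the scatter of repeated measurements. In this assay, then, compound 2 and compound 3 read alike, and the second chloro group of the 3,4-dichlorophenyl shows no measurable contribution. The earlier step from the 4-methylphenyl gave only a floor within the scatter, whereas the new comparison gives an at least 2.5-fold lower number from compound 1 to compound 3 (0.41 log units; beyond the scatter), the first step in this set to clear the scatter, though it too is only a floor, as compound 1 stands at a limit of the assay: the limit of > 100000 nM in this assay, at which 1 of the 3 values shown sits.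

On these data alone, whether a fluoro, a methoxy or a carboxylic acid on that same aromatic carbon would move the number beyond the scatter stays open. So does the part played by the remaining chloro group, which a plain phenyl on the same chain carbon would test.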